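Nitro in Place of Chloro: What Compound 4 Might Show

A few compounds are considered here, and "the series" means these few. Any claim that something is new, unique, unknown or untested is made for them only; others in the source may bear on it.

Measured so far in a functional assay on the whole organism (strain Wistar) for inhibition, with Rattus norvegicus as the target, with stated times of 30 min and 3 h, at a dose of 20 mg/kg by the oral route; on this read-out higher numbers stand for more inhibition at the one dose given (going by the name of the read-out) and lower numbers for less inhibition:
compound 1 `O=C(CCc1nnc(-c2ccc(Cl)cc2)o1)c1ccccc1` gives 81.5%
compound 2 `O=C(CCc1nnc(-c2ccc([N+](=O)[O-])cc2)o1)c1ccccc1` gives 62.7%
compound 3 `Cc1ccc(C(=O)CCc2nnc(-c3ccc(Cl)cc3)o2)c(C)c1` gives 72.6%

Compound 3 differs from compound 1 by 2,4-dimethylphenyl in place of phenyl on a carbonyl carbon, and the step of a number 8.9 percentage points lower from compound 1 to compound 3 (within the scatter) lies within the scatter, so the two values cannot be ordered. Compound 2 differs from compound 1 by nitro in place of chloro on an aromatic carbon, and here the step of a number 18.8 percentage points lower from compound 1 to compound 2 (beyond the scatter) is beyond the scatter.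

Compound 4 `Cc1ccc(C(=O)CCc2nnc(-c3ccc([N+](=O)[O-])cc3)o2)c(C)c1` has not yet been measured in this assay. It differs from compound 3 by nitro in place of chloro on an aromatic carbon. The place of this change is the same, word for word, as for the change from compound 1 to compound 2, so it is the same change made on the core of compound 3 instead of the core of compound 1. Among the compounds with values here, the step expected for compound 4 is therefore a number 18.6 percentage points lower from compound 3 to compound 4 (beyond the scatter), because a number 18.8 percentage points lower from compound 1 to compound 2 (beyond the scatter) is the only measured step available for this change. On that basis compound 4 is estimated to give 54% in this assay, expected to fall between 40% and 68%.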

Compound 4, a percentage reported as inhibition, in the whole organism at one dose (the size of the read-out at that dose, not a potency): 69.1%
Beside the measured number, compound 4's estimate is 15.1 percentage points below it; measured number outside the range, above it.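

In this assay, nitro in place of chloro on an aromatic carbon gives a number 3.5 percentage points lower from compound 3 to compound 4 (within the scatter), so on this core the two values cannot be ordered, and the earlier step does not carry over in size: the same change on two cores in this assay, a number 18.8 percentage points lower (beyond the scatter) from compound 1 to compound 2 and a number 3.5 percentage points lower (within the scatter) from compound 3 to compound 4, 15.3 percentage points apart, beyond the scatter of two such steps. The other change, 2,4-dimethylphenyl in place of phenyl on a carbonyl carbon, gives a number 6.4 percentage points higher from compound 2 to compound 4 (within the scatter), and neither this step nor its earlier counterpart can be read as a change on its own, yet the two also stand apart: the same change on two cores in this assay, a number 8.9 percentage points lower (within the scatter) from compound 1 to compound 3 and a number 6.4 percentage points higher (within the scatter) from compound 2 to compound 4, 15.3 percentage points apart, beyond the scatter of two such steps. Together these steps show that, among these four compounds, the effect of one change depends on what else the molecule carries, but with a single pair of cores they do not show why, nor what the nitro step would be on any other core.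

The compounds shown leave open how an amine or a methoxy group in place of chloro would read at this one dose. They also leave open whether a longer chain than the one shared by all four compounds would alter these steps.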